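Chain-amine variation in the stilbene ether series

The source may hold more compounds than are shown below. What is called first, only, known or untested is meant among the compounds shown, and "the series" means these compounds.

Of the compounds shown here, three have been measured in a functional assay on the whole organism with Mus musculus as the target, in the maximal electroshock model, at a dose of 50 mg/kg by the oral route; a lower number here means less inhibition, a higher number more inhibition at the dose given (going by the name of the read-out). Compound 1 `CN(C)CCCOc1ccccc1/C=C/c1ccccc1` gives 14.2%. Compound 2 `CN(C)CCCCOc1ccccc1/C=C/c1cccc(Cl)c1` gives 14.3%. Compound 3 `C(=C/c1ccccc1OCCCCN1CCCCC1)\c1ccccc1` gives 42.9%, the highest of the three numbers; compound 2 is nearest and compound 1 furthest, both beyond the scatter. Compounds 1 and 2 differ in more than one place, so their two values are simply noted side by side. Within the data shown here, the one single-point step known is a number 28.7 percentage points higher from compound 1 to compound 3 (beyond the scatter), a modest rise.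

Compound 4 `CCCN1CCN(CCCCOc2ccccc2/C=C/c2ccccc2)CC1` is not yet measured. It differs from compound 3 in one place: 4-propylpiperazin-1-yl in place of piperidin-1-yl on a saturated chain carbon, four bonds along the chain from an oxygen on an aromatic ring. Among the measured compounds shown here, no measured step tests this exact change; the step from compound 1 to compound 3 concerns the same region of the molecule and showed that replacing the amine end can move this assay by a modest amount, but it gives no direction for the present swap. The starting point is the highest number in the set, so some fall is as plausible as a further rise. The expected step is a number 4.9 percentage points lower from compound 3 to compound 4 (within the scatter), roughly no move beyond the scatter. Compound 4 is therefore estimated at 38%, with a range from 15% to 62%.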

Compound 4, a percentage reported as inhibition, in the whole organism at one dose (the size of the read-out at that dose, not a potency): 42.9%
Estimate against measurement, compound 4: 4.9 percentage points below; measured number inside the range.
By their numbers in this assay, from the lowest: compounds 1 and 2 (each within the scatter of the next); then compounds 3 and 4 (each within the scatter of the next).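

In this assay, among these compounds, the exchange of piperidin-1-yl for 4-propylpiperazin-1-yl on the saturated chain carbon, four bonds along the chain from an oxygen on an aromatic ring, gives no change at the digits printed from compound 3 to compound 4 (within the scatter) and is the first single-point step without a move beyond the scatter. The earlier a number 28.7 percentage points higher from compound 1 to compound 3 (beyond the scatter) showed that a change at the amine end can shift the read-out; this step shows that, with the four-bond chain kept, the ring can grow from 6 to 9 heavy atoms and gain a second ring nitrogen without such a shift. No available evidence bears on why the two rings read alike.

Each read-out is taken at one dose, so the matching numbers for compound 3 and compound 4 say nothing about relative potency, and they leave open how far this level extends across amine ends. Morpholin-4-yl or an unsubstituted piperazin-1-yl at the same chain carbon, or a chain longer than the one carrying these two rings, would test that extent directly.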